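Hydrogen in place of chloro in compound 2

A few compounds are considered here, and "the series" means these few. Any claim that something is new, unique, unknown or untested is made for them only; others in the source may bear on it.

Measured in a functional assay on CCRF-CEM cells (Homo sapiens) for antiproliferative activity, read by cell counting, with a stated time of 2 days; on this read-out lower numbers stand for stronger inhibition and higher numbers for weaker inhibition:
- compound 1 `COc1ccccc1C(=O)c1sc(N2CCCC2)nc1N`: 171000 nM
- compound 2 `Nc1nc(N2CCCC2)sc1C(=O)c1ccc(Cl)cc1`: > 200000 nM

The reading for compound 2 is a limit of the assay and not a number: the limit of > 200000 nM in this assay, at which 1 of the 2 values shown sits. Compound 2 `Nc1nc(N2CCCC2)sc1C(=O)c1ccc(Cl)cc1` therefore has no exact position in the series. Compound 3 `Nc1nc(N2CCCC2)sc1C(=O)c1ccccc1` differs from compound 2 at one place: hydrogen in place of chloro on an aromatic carbon, with hydrogen in place of chloro on an aromatic carbon, para to a large group. Within the data shown here, no measured pair shows this change, so the expectation rests on few data. Among the measured compounds shown here, compound 1, at 171000 nM, gives the only exact number for the shared core. In this assay, the expected step of an at least 1.1-fold lower number from compound 2 to compound 3 (0.04 log units; that floor lies within the scatter) is none beyond the scatter, with no direction favoured. For compound 3 the estimated value is 180000 nM, with an expected range of 90000 nM to 300000 nM.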

Compound 3, half-maximal inhibitory concentration: > 200000 nM
Compound 3: no number, only a limit; the forecaster's own chance of this, stated with the estimate: 45%; middle value at least 1.1-fold (0.04 log units) from the limit.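

Like compound 2, compound 3 reads only as a limit and not a number in this assay, so the step for hydrogen in place of chloro cannot be read. Hydrogen in place of methoxy does give a bounded step, an at least 1.1-fold higher number from compound 1 to compound 3 (0.06 log units; that floor lies within the scatter), but that bound stays within the scatter and shows no real separation between the two compounds. Compound 1 remains the only compound with an exact number, and the series now sits mostly at the edge of what the assay can read: the limit of > 200000 nM in this assay, at which 2 of the 3 values shown sit.

As far as these compounds go, it remains open whether any group on this aromatic ring can give a number clearly separated from that of compound 1. An amine or a carboxylic acid para to a large group, or a longer chain in place of methoxy, would bear on this.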